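Amine substituent change in the enaminone series

A few compounds are considered here, and "the series" means these few. Any claim that something is new, unique, unknown or untested is made for them only; others in the source may bear on it.

Compound 2 `O=C(/C=C\Nc1cnc2ccccc2c1)c1nc(-c2ccc(C(F)(F)F)cc2)n2ccccc12` stands only at a limit of a functional assay on BT-474 cells (Homo sapiens) for cytotoxicity, read by MTT assay, with a stated time of 48 h; a lower number here means a stronger inhibitor, a higher number a weaker inhibitor. In this assay compound 2 gives > 30000 nM, which is a limit and not a number. Compound 1 `COc1ccc(N/C=C\C(=O)c2nc(-c3ccc(C(F)(F)F)cc3)n3ccccc23)cc1OC` also reaches only a limit in this assay, giving > 30000 nM. The step from 3,4-dimethoxyphenyl to quinolin-3-yl on the amine nitrogen, a step that the two limits leave unreadable from compound 1 to compound 2, cannot be read since both compounds sit at the same limit (the limit of > 30000 nM in this assay, at which 2 of the 2 values shown sit). Compound 3 `COc1ccc(N/C=C\C(=O)c2nc(-c3ccc(C(F)(F)F)cc3)n3ccccc23)cc1` carries the change (4-methoxyphenyl in place of quinolin-3-yl on an amine nitrogen). Among the compounds with values here, no measured step bears on it beyond the unreadable one from compound 1 to compound 2, and the two values shown give only that neither compound reaches a number. The expectation for compound 3 is therefore a step that the limit leaves unreadable from compound 2 to compound 3, with the value again expected at or beyond the limit. Compound 3 is estimated at 50000 nM, in the range 20000 nM to 200000 nM.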

Compound 3, half-maximal inhibitory concentration: > 30000 nM
Compound 3: no number, only a limit; the forecaster's own chance of this, stated with the estimate: 85%; the middle value does not contradict the limit.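

No step among compound 1, compound 2 and compound 3 can be read in this assay, since all three stand at one limit and give no number: the limit of > 30000 nM in this assay, at which 3 of the 3 values shown sit.

The compounds shown leave open whether any change of the amine substituent on the shared core gives a readable value in this assay, and how these three substituents rank.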